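Lengthening the hydroxyalkyl chain of compound 2

The compounds below may be only part of what the source reports. "The series", "measured", "known", "first", "only" and "open" are said of these compounds alone.

Measured so far in a functional assay on NCI-H460 cells (Homo sapiens) for inhibition, read by MTT assay, with a stated time of 4 days (on this read-out higher numbers stand for weaker inhibition and lower numbers for stronger inhibition), and shown here

Compound 1 `COc1cc(NC(C)CCCNC(=O)NNC(=O)Nc2ccc(Cl)c(C(F)(F)F)c2)c2ncccc2c1` gives 13000 nM
Compound 2 `COc1cc(NC(C)CCCNC(=O)NNC(=O)NCCO)c2ncccc2c1` gives > 100000 nM as a limit
Compound 3 `O=C(NC(c1ccccc1)c1ccc(Cl)cc1)n1nnc2ccccc21` gives 18000 nM

Compound 2 stands at the limit of > 100000 nM in this assay, at which 1 of the 3 values shown sits, so it is known only as a limit and not as a number. Compound 4 `COc1cc(NC(C)CCCNC(=O)NNC(=O)NCCCO)c2ncccc2c1` differs from it by hydroxymethyl in place of hydroxy on a saturated chain carbon, two bonds along the chain from an amide-type nitrogen, which is hydroxymethyl in place of hydroxy on a saturated chain carbon, two bonds along the chain from an amide-type nitrogen. The same difference reads 2-hydroxyethyl to 3-hydroxypropyl. For the measured compounds named here, one measured step bears on this change: an at least 7.6-fold higher number from compound 1 to compound 2 (0.88 log units; beyond the scatter), beyond the scatter, with 2-hydroxyethyl in place of 4-chloro-3-(trifluoromethyl)phenyl on an amide-type nitrogen. That step took a ring away, while here no ring leaves or enters. Going by the values given here, no single-place step links compound 3 to the others. The expectation in this assay is therefore a step that the limit leaves unreadable from compound 2 to compound 4, with no change beyond the scatter and a reading that may again be only a limit. The estimate for compound 4 is 120000 nM (expected range 40000 nM to 300000 nM) and awaits measurement.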

Compound 4, half-maximal inhibitory concentration: > 100000 nM
Compound 4 ended at the assay's limit; the forecaster's own chance of this, stated with the estimate: 75%; the middle value lies beyond the limit too.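

Lengthening the chain by one carbon did not bring a measurable reading in this assay. The step from 2-hydroxyethyl to 3-hydroxypropyl cannot be read, and its size stays unknown because both compounds stop at the assay's limit: the limit of > 100000 nM in this assay, at which 2 of the 4 values shown sit.

Putting 3-hydroxypropyl in place of 4-chloro-3-(trifluoromethyl)phenyl on the amide-type nitrogen gives an at least 7.6-fold higher number from compound 1 to compound 4 (0.88 log units; beyond the scatter), so among the compounds shown, the rise seen with 2-hydroxyethyl also holds for a second hydroxyalkyl chain.

The compounds shown leave open whether a longer hydroxyalkyl chain, or an amine or a carboxylic acid at the end of the chain, would give a reading inside the range of the assay. They also leave open whether an unsubstituted phenyl on this nitrogen would keep a number like that of compound 1.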